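The compounds below may be only part of what the source reports. "The series", "measured", "known", "first", "only" and "open" are said of these compounds alone.

Compound 1 `O=C(NS(=O)(=O)c1ccccc1)c1cccnc1Cl`: 14000 nM
Compound 2 `O=C(NS(=O)(=O)c1ccc(F)cc1)c1cccnc1Cl`: 12500 nM

For the measured compounds named here, in a functional assay on MCF7 cells (Homo sapiens) for antiproliferative activity, read by MTT assay, with a stated time of 48 h (on this read-out lower numbers stand for stronger inhibition and higher numbers for weaker inhibition), compound 1 gives 14000 nM, which lies within the usual scatter of compound 2, the only other measured compound. Compound 3 `Cc1ccc(C(=O)NS(=O)(=O)c2ccccc2)c(Cl)n1` keeps the core of compound 1 with one change: methyl in place of hydrogen on an aromatic carbon, next to the ring nitrogen (methyl in place of hydrogen on an aromatic carbon). Going by the values given here, the one measured step, a 1.1-fold lower number from compound 1 to compound 2 (0.05 log units; within the scatter), is a fluoro replacement at another place, so it is only a loose guide. No step beyond the scatter is therefore expected in this assay. The expected step is a 1.2-fold lower number from compound 1 to compound 3 (0.07 log units; within the scatter). For compound 3 the estimate is 12000 nM, with an expected range from 5000 nM to 30000 nM.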

Compound 3, half-maximal inhibitory concentration: 13400 nM
For compound 3 the middle estimate is 1.1-fold (0.05 log units) below the measured one; the measured number falls inside the stated range.
By their numbers in this assay, from the lowest: compounds 2, 3 and 1 (each within the scatter of the next).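

Measured in this assay methyl in place of hydrogen on the aromatic carbon next to the ring nitrogen gives a 1.0-fold lower number from compound 1 to compound 3 (0.02 log units; within the scatter) so this place on the core of compound 1 takes a methyl group without a step beyond the scatter. The earlier step spoke only of a fluoro replacement at another place. No measurement at hand offers an explanation for this result. Going by these compounds, whether a longer chain, an amine or a carboxylic acid at this same place would also stay within the scatter remains open. A single methyl group speaks only for methyl.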